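Sulfonamide amines against pancreatic cancer cells: a benzyl swap

The compounds below may be only part of what the source reports. "The series", "measured", "known", "first", "only" and "open" are said of these compounds alone.

Measured compounds:
compound 1 `CC(C)(C)c1ccc(CNCCCNS(=O)(=O)c2cc(C(F)(F)F)cc(C(F)(F)F)c2)cc1` — 2300 nM
compound 2 `O=S(=O)(NCCCCCCNCc1ccc(Br)cc1)c1cccc(C(F)(F)F)c1` — 5970 nM

Of the compounds shown here, two have been tested in a functional assay on MIA PaCa-2 cells (Homo sapiens) for inhibition, read by MTT assay, with a stated time of 72 h; on this read-out lower numbers stand for stronger inhibition of growth and higher numbers for weaker inhibition of growth. Compound 1 gives 2300 nM and compound 2 gives 5970 nM. Compound 1 thus holds the lowest number of the two, and the gap between compound 1 and compound 2 lies beyond the scatter.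

Compound 3 `O=S(=O)(NCCCNCc1cccc(Cl)c1)c1cc(C(F)(F)F)cc(C(F)(F)F)c1` has not yet been measured. It derives from compound 1 by a single change: 3-chlorophenyl in place of 4-(tert-butyl)phenyl on a saturated chain carbon bound to an amine nitrogen. Among the compounds with values here, no measured pair shows this particular change, so its effect can only be guessed. Because compound 1 sits at 2300 nM and compound 2, with a different halogenated benzyl group, sits at 5970 nM, a modest rise in number is expected rather than a fall. The expected step of a 1.7-fold higher number from compound 1 to compound 3 (0.24 log units; within the scatter) is estimated as small, near the edge of the scatter. Compound 3 is therefore estimated at 4000 nM, with a range from 1500 nM to 11000 nM.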

Compound 3, concentration for 50% growth inhibition: 4400 nM
The estimate for compound 3 lay 1.1-fold (0.04 log units) below the measured number, and the stated range covers the measured number.
By their numbers in this assay, from the lowest: compounds 1, 3 and 2 (each within the scatter of the next, the first and the last beyond it).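

Exchanging 4-(tert-butyl)phenyl for 3-chlorophenyl on the saturated chain carbon bound to an amine nitrogen gives, in this assay, a 1.9-fold higher number from compound 1 to compound 3 (0.28 log units; within the scatter) even though the entering group has fewer heavy atoms than the leaving one. Within the data shown here, this is the first single-place comparison, and at this place the two aryl groups are not separated by the read-out. Nothing available explains why the change leaves so little mark.

As far as these compounds go, whether an unsubstituted benzyl group or a pyridine ring at this place would also stay within the scatter remains open. Compound 2 differs from compound 1 and compound 3 in more than one place, so the separate contributions of its longer chain and its 4-bromobenzyl group cannot be read.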